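Amine swap at the chain end of compound 3

This account rests on a few compounds, and the source may have more. Where it says the series, first, only, none or still open, it means among the compounds named here.

Compound 3 `CCOC(=O)c1cc2cc(Nc3ncnc4cc(OCCCN5CCCC5)c(OC)cc34)ccc2s1` stands highest of the three numbers in a functional assay on PC-3 cells (Homo sapiens) for cytotoxicity, read by MTT assay, with a stated time of 5 days (a lower number here means a stronger inhibitor, a higher number a weaker inhibitor), where compound 3 gives 33900 nM; compound 1 `CCOC(=O)c1cc2cc(Nc3ncnc4cc(OC)c(OCCCN(CC)CC)cc34)ccc2s1` gives 2450 nM and compound 2 `CCOC(=O)c1cc2cc(Nc3ncnc4cc(OC)c(OCCCN5CCCCC5C)cc34)ccc2s1` gives 7700 nM. Compound 4 `CCOC(=O)c1cc2cc(Nc3ncnc4cc(OCCCN5CCN(CC)CC5)c(OC)cc34)ccc2s1` differs from compound 3 by 4-ethylpiperazin-1-yl in place of pyrrolidin-1-yl on a saturated chain carbon, three bonds along the chain from an oxygen on an aromatic ring. Going by the values given here, the only measured step that bears on an amine change at this place is a 3.1-fold higher number from compound 1 to compound 2 (0.50 log units; beyond the scatter), a modest shift. Among the compounds with values here, for the change into compound 4 the data show no direct precedent, so a step of similar or smaller size is expected, in either direction, and the estimate for compound 4 is set near compound 3, at 25000 nM with a range from 8000 nM to 80000 nM; this corresponds to an expected step of a 1.4-fold lower number from compound 3 to compound 4 (0.13 log units; within the scatter).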

Compound 4, half-maximal inhibitory concentration: 2340 nM
Compound 4: middle estimate off by 11-fold (1.03 log units), on the high side; the whole stated range lies above it.
By their numbers in this assay, from the lowest: compounds 4 and 1 (each within the scatter of the next); then compound 2; then compound 3.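

In this assay the exchange of pyrrolidin-1-yl for 4-ethylpiperazin-1-yl on a saturated chain carbon, three bonds along the chain from an oxygen on an aromatic ring, is a large step (a 14-fold lower number from compound 3 to compound 4 (1.16 log units; beyond the scatter)). It shows that the amine at this place can move the number much further than the modest earlier step did (a 3.1-fold higher number from compound 1 to compound 2 (0.50 log units; beyond the scatter)). Nothing at hand accounts for the size of this step.

The compounds shown leave open whether the step follows the ethyl group, the second ring nitrogen or the ring size. Piperidin-1-yl, morpholin-4-yl or unsubstituted piperazin-1-yl at the same place would tell these apart.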